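The compounds below may be only part of what the source reports. "The series", "measured", "known", "first", "only" and "open" are said of these compounds alone.

Working notes on the series.

In a functional assay on A549 cells (Homo sapiens) for cytotoxicity, read by MTT assay, with a stated time of 48 h (on this read-out lower numbers stand for stronger inhibition and higher numbers for weaker inhibition), compound 1 `Cc1ccc(Cn2c(/C=C3\SC(=S)N(CC(=O)O)C3=O)nc3cc(F)ccc32)cc1` gives 13800 nM. Compound 2 `COc1ccc2c(c1)nc(/C=C1\SC(=S)N(CC(=O)O)C1=O)n2Cc1ccc(C)cc1` carries the change methoxy in place of fluoro on an aromatic carbon on the same core, and in this assay compound 2 gives 5680 nM, a step of a 2.4-fold lower number from compound 1 to compound 2 (0.39 log units; beyond the scatter). Compound 3 `O=C(O)CN1C(=O)/C(=C/c2nc3cc(F)ccc3n2Cc2ccccc2F)SC1=S` differs from compound 1 in its core by 2-fluorophenyl in place of 4-methylphenyl on a saturated chain carbon bound to an aromatic nitrogen; in this assay compound 3 gives 32700 nM, the step being a 2.4-fold higher number from compound 1 to compound 3 (0.37 log units; beyond the scatter). Compound 4 `COc1ccc2c(c1)nc(/C=C1\SC(=S)N(CC(=O)O)C1=O)n2Cc1ccccc1F` is not yet measured; it differs from compound 3 by methoxy in place of fluoro on an aromatic carbon, the same change as from compound 1 to compound 2, now made on the core of compound 3. Going by the values given here, for compound 4 the expected step is a 2.4-fold lower number from compound 3 to compound 4 (0.38 log units; beyond the scatter), resting on the one earlier example a 2.4-fold lower number from compound 1 to compound 2 (0.39 log units; beyond the scatter); no second measured example of this change exists, so the expectation is wide. Compound 4 is estimated at 13600 nM, between 6000 nM and 30000 nM.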

Compound 4, half-maximal inhibitory concentration: 18400 nM
The estimate for compound 4 lay 1.4-fold (0.13 log units) below the measured number; measured number inside the range.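

In this assay, methoxy in place of fluoro on an aromatic carbon gives a 1.8-fold lower number from compound 3 to compound 4 (0.25 log units; within the scatter), and this change carries across the two cores: the same change on two cores in this assay, a 2.4-fold lower number (0.39 log units; beyond the scatter) from compound 1 to compound 2 and a 1.8-fold lower number (0.25 log units; within the scatter) from compound 3 to compound 4, 1.4-fold (0.14 log units) apart, within the scatter of two such steps. 2-Fluorophenyl in place of 4-methylphenyl gives a 3.2-fold higher number from compound 2 to compound 4 (0.51 log units; beyond the scatter), and this change carries across in the same way: the same change on two cores in this assay, a 2.4-fold higher number (0.37 log units; beyond the scatter) from compound 1 to compound 3 and a 3.2-fold higher number (0.51 log units; beyond the scatter) from compound 2 to compound 4, 1.4-fold (0.14 log units) apart, within the scatter of two such steps. Each comparison, however, rests on only one pair of steps, and the methoxy step on the core of compound 3 is itself within the scatter, so no rule beyond these four compounds is shown.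

Still open, on these data alone, is whether these steps hold with an amine or a nitrile on the same aromatic carbon. Also open, as far as these compounds go, is how an amide in place of the carboxylic acid would behave.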